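A few compounds are considered here, and "the series" means these few. Any claim that something is new, unique, unknown or untested is made for them only; others in the source may bear on it.

Measured compounds:
- compound 1, `CCCCCCc1cc2cn(Cc3cn(Cc4ccccc4)nn3)c(=O)nc2o1`: 68700 nM
- compound 2, `CCCCCc1ccc(C#Cc2c(-c3ccc(CCCCC)cc3)oc3nc(=O)n(Cc4cn(-c5ccccc5F)nn4)cc23)cc1`: 72500 nM
- compound 3, `O=c1nc2oc(CCCCl)cc2cn1Cc1cn(-c2ccc(F)cc2)nn1`: 14600 nM

All three were tested in a functional assay on HepG2 cells (Homo sapiens) for antiproliferative activity, read by MTT assay, with a stated time of 72 h (on this read-out higher numbers stand for weaker inhibition and lower numbers for stronger inhibition), and all three sit at weak inhibition. Compound 1 stands at the second highest number of the three. Its nearest neighbour is compound 2, whose number is slightly higher but within the scatter of this assay, so the two cannot be told apart. Compound 3 is the furthest from compound 1, with a lower number that lies beyond the scatter, meaning compound 3 inhibits growth more strongly than compound 1 in this assay.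

The step now considered leads from compound 1 to compound 4, `O=c1nc2oc(C3CC3)cc2cn1Cc1cn(Cc2ccccc2)nn1`, which has not yet been measured. The change is cyclopropyl in place of hexyl on an aromatic carbon. Among the measured compounds shown here, nothing among the measured compounds isolates this exact exchange, so there is no measured step to lean on; the difference between compound 1 and compound 3 involves more than one alteration and only shows what those two values show.

For the measured compounds named here, with no direct precedent, the expectation for this step is a small move, if any, likely staying within the scatter, and the estimated step from compound 1 to compound 4 is a 1.4-fold lower number from compound 1 to compound 4 (0.14 log units; within the scatter). Compound 4 is therefore expected to give about 50000 nM in this assay, within a range from 15000 nM to 160000 nM.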

Compound 4, half-maximal inhibitory concentration: 49100 nM
Compound 4: middle estimate off by 1.0-fold (0.01 log units), on the high side; the measured number falls inside the stated range.
By their numbers in this assay, from the lowest: compound 3; then compounds 4, 1 and 2 (each within the scatter of the next).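

In this assay, putting cyclopropyl in place of hexyl on this aromatic carbon, next to the ring oxygen, gives a 1.4-fold lower number from compound 1 to compound 4 (0.15 log units; within the scatter), so the two compounds cannot be told apart. Among the compounds shown here, this is the first exchange that changes only this one place, and it shows that the group here can go from an open chain of 6 carbons to a small ring of 3 carbons without a change that can be read in this assay. Inhibition stays weak with both groups, so neither the full length of the hexyl chain nor the ring of the cyclopropyl stands out here, and no measurement at hand offers an explanation for this result.

As far as these compounds go, with only these two groups compared on the shared core, it remains open whether a chain of intermediate length, such as butyl, would also leave the number in place. From the compounds shown here alone, it also remains open whether a quite different group at this carbon, such as an amine or a carboxylic acid, would give a number clearly apart from those of compound 1 and compound 4.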